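This account rests on a few compounds, and the source may have more. Where it says the series, first, only, none or still open, it means among the compounds named here.

Of the compounds shown here, three have been measured in a functional assay on HEK293 cells for antagonist activity at corticotropin-releasing factor receptor 1 (Homo sapiens), read by fluorescence and cAMP accumulation, with a stated time of 30 min; on this read-out lower numbers stand for stronger inhibition and higher numbers for weaker inhibition. Compound 1 `COCc1cc(OC)c(-c2cccc3c(N(CC4CCOCC4)CC4CC4)c(C)nn23)c(OC)c1` gives 50 nM. Compound 2 `CCc1nn2c(-c3ccc(OC)cc3Cl)cccc2c1N(CC1CC1)CC1CC1` gives 100 nM, and compound 3 `COCc1cc(OC)c(-c2cccc3c(N(CC4CCOCC4)CC4CC4)c(OC)nn23)c(OC)c1` gives 110 nM. Compound 1 has the lowest number of the three; its value and that of compound 2 lie within the scatter of each other, whereas the step of a 2.2-fold higher number from compound 1 to compound 3 (0.34 log units; beyond the scatter) lies beyond it.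

Compound 4 `CCc1nn2c(-c3c(OC)cc(COC)cc3OC)cccc2c1N(CC1CCOCC1)CC1CC1` differs from compound 1 by methyl in place of hydrogen on a saturated chain carbon bound to an aromatic carbon. Going by the values given here, no measured step covers this change on its own. Compound 2 carries an ethyl group on its core, as compound 4 does, but it differs from compound 1 in several further places, so its value and that of compound 1 only show that the two lie close together. Among the compounds with values here, the single measured step at this site, from compound 1 to compound 3, put methoxy in place of methyl and was modest. For compound 4 the step of a 1.3-fold higher number from compound 1 to compound 4 (0.11 log units; within the scatter) is therefore expected to be small, a slight weakening at most. Compound 4 is estimated at 65 nM, with a range from 30 nM to 140 nM.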

Compound 4, half-maximal inhibitory concentration: 23 nM
Compound 4: middle estimate off by 2.8-fold (0.45 log units), on the high side; the whole stated range lies above it.
By their numbers in this assay, from the lowest: compound 4; then compounds 1, 2 and 3 (each within the scatter of the next, the first and the last beyond it).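

Replacing methyl with ethyl on this aromatic carbon of the shared core gives a 2.2-fold lower number from compound 1 to compound 4 (0.34 log units; beyond the scatter), so this position accepts the extra carbon and the number falls rather than rises. Ethyl in place of methoxy gives a 4.8-fold lower number from compound 3 to compound 4 (0.68 log units; beyond the scatter), the widest step at this site, and the three groups now order as ethyl, methyl and methoxy from the lowest number to the highest. The data shown offer no explanation for this order.

As far as these compounds go, whether the number keeps falling with a longer chain such as propyl, or changes with a branched isopropyl or a cyclopropyl ring, remains open. Also open, from the compounds shown here alone, is whether ethyl keeps its edge when other parts of the molecule change, as compound 2 carries ethyl but differs from compound 4 in more than one place.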